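Trifluoromethyl for Pentafluorosulfanyl on an Anilide Series

This account rests on a few compounds, and the source may have more. Where it says the series, first, only, none or still open, it means among the compounds named here.

Of the compounds shown here, three of this set have been measured in a functional assay on CWR22R cells (Homo sapiens) for antiproliferative activity, read by propidium iodide staining, with a stated time of 96 h; on this read-out higher numbers stand for weaker inhibition and lower numbers for stronger inhibition. Compound 1 `CC(O)(CSc1cccc(S(F)(F)(F)(F)F)c1)C(=O)Nc1ccc(S(F)(F)(F)(F)F)cc1` gives 17700 nM in this assay. Compound 2 `CC(O)(CSc1cccc(C(F)(F)F)c1)C(=O)Nc1ccc(S(F)(F)(F)(F)F)cc1` differs from compound 1 in one place: a group of 4 heavy atoms (1 carbon, 3 fluorine; no ring) in place of a group of 6 heavy atoms (5 fluorine, 1 sulfur; no ring), on an aromatic carbon. Compound 2 gives 23400 nM in this assay. Within this assay the change gave a 1.3-fold higher number from compound 1 to compound 2 (0.12 log units; within the scatter). Compound 3 `CC(O)(COc1ccc(S(F)(F)(F)(F)F)cc1)C(=O)Nc1ccc(S(F)(F)(F)(F)F)cc1` returns 13000 nM in this assay; its number stands near those of compound 1 and compound 2, and the differences among the three are all within the scatter. How the core of compound 3 differs from the core of compound 1 is not broken down here.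

Compound 4 `CC(O)(COc1ccc(S(F)(F)(F)(F)F)cc1)C(=O)Nc1ccc(C(F)(F)F)cc1` has not yet been measured. It differs from compound 3 in this way: a group of 4 heavy atoms (1 carbon, 3 fluorine; no ring) in place of a group of 6 heavy atoms (5 fluorine, 1 sulfur; no ring), on an aromatic carbon. This is the same kind of change as that from compound 1 to compound 2, though not the same: in the earlier pair the place was meta to a large group, whereas here it is para to a large group. Among the measured compounds shown here, the earlier step was within the scatter, and with only one measured example of this kind of change there is little reason to expect a larger step now. The account therefore expects for the step from compound 3 to compound 4 in this assay about a 1.3-fold higher number from compound 3 to compound 4 (0.10 log units; within the scatter), resting on the step from compound 1 to compound 2, which was a 1.3-fold higher number from compound 1 to compound 2 (0.12 log units; within the scatter). For compound 4 in this assay the estimate is 16500 nM, expected to lie between 8000 nM and 34000 nM.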

Compound 4, half-maximal inhibitory concentration: 12900 nM
For compound 4 the middle estimate is 1.3-fold (0.11 log units) above the measured one; low and high end bracket the measured number.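

In this assay, trifluoromethyl in place of the group of five fluorine atoms and one sulfur, on an aromatic carbon para to a large group, gave a 1.0-fold lower number from compound 3 to compound 4 (0.00 log units; within the scatter). Set beside the earlier case, the change carries from one core to the other without a step that can be told from the scatter, and the two steps do not differ from each other: the same change on two cores in this assay, a 1.3-fold higher number (0.12 log units; within the scatter) from compound 1 to compound 2 and a 1.0-fold lower number (0.00 log units; within the scatter) from compound 3 to compound 4, 1.3-fold (0.12 log units) apart, within the scatter of two such steps. Among the compounds shown here, this shows only that the exchange left the number unresolved from its parent in these two pairs, all at a similar level of inhibition; it does not show that the two groups are interchangeable in general, since two pairs is a small base, the change sits at a different place in each pair, and a core with much stronger inhibition might respond differently.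

The compounds shown leave open whether a nitrile or a single chlorine atom on the same aromatic carbon would give a number in this range. They also leave open whether a sulfonyl link in place of the sulfur or oxygen in the chain would shift the number, and whether the exchange would then still pass unnoticed.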